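Removing a fluoro from compound 3

This account rests on a few compounds, and the source may have more. Where it says the series, first, only, none or still open, it means among the compounds named here.

- compound 1 `O=C(O)c1cn(Cc2ccc(-n3cccn3)cc2)c2cccc(F)c2c1=O`: 88.4%
- compound 2 `O=C(O)c1cn(Cc2ccc(N3CCOC3=O)cc2)c2cccc(F)c2c1=O`: 88.4%
- compound 3 `O=C(O)c1cn(Cc2ccc(-n3cccn3)cc2)c2c(F)ccc(F)c2c1=O`: 95.7%

In an ADME assay on a cell-free system (plasma, Rattus norvegicus) for protein binding, compound 3, at 95.7%, has the lowest unbound fraction of the three. Compound 4 `O=C(O)c1cn(Cc2ccc(-n3cccn3)cc2)c2c(F)cccc2c1=O` differs from compound 3 by hydrogen in place of fluoro on an aromatic carbon. The change is hydrogen in place of fluoro on an aromatic carbon, para to a fluoro group. The closest measured change is a 2.7-fold lower unbound fraction from compound 1 to compound 3 (0.43 log units; beyond the scatter). That fluoro sits on a different carbon, and compound 4 keeps it, so the transfer is only approximate. The change no change at the digits printed from compound 1 to compound 2 (within the scatter) concerns another group and gives no guidance. A step of similar size towards more free compound is expected. The expected change is a 2.1-fold higher unbound fraction from compound 3 to compound 4 (0.32 log units; beyond the scatter). For compound 4 the estimate is 91%, with an expected range of 85% to 95.5%.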

Compound 4, plasma protein binding: 98%
Compound 4: middle estimate off by 4.5-fold (0.65 log units) (unbound fraction), on the high side, and the stated range ends below it.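

Loss of the fluoro para to a fluoro group gives a 2.2-fold lower unbound fraction from compound 3 to compound 4 (0.33 log units; beyond the scatter) in this assay and so moves the read-out towards more bound compound. Entry of a fluoro on the other carbon gave a 2.7-fold lower unbound fraction from compound 1 to compound 3 (0.43 log units; beyond the scatter) in the same direction, so a step at one carbon of this ring does not carry over to another. Nothing at hand explains this result.

Open, on these data alone, is how a chloro or methoxy group on this carbon would read. Also open, as far as these compounds go, is whether the step holds with 2-oxo-1,3-oxazolidin-3-yl in place of 1H-pyrazol-1-yl.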